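From compound 2 to compound 4: the amide end

This account rests on a few compounds, and the source may have more. Where it says the series, first, only, none or still open, it means among the compounds named here.

Among the measured compounds shown here, in a functional assay on DU-145 cells (Homo sapiens) for antiproliferative activity, read by sulforhodamine B assay, with a stated time of 48 h (on this read-out higher numbers stand for weaker inhibition and lower numbers for stronger inhibition), compound 2 (`CCCCN(C)C(=O)CCCCOc1cc(OC)c(OC)c2oc(-c3ccc(OC)cc3)c(O)c(=O)c12`) gives 10800 nM as the only actual number in the set. Compound 1 (`COc1ccc(-c2oc3c(OC)c(OC)cc(OCCCC(=O)N4CCN(C)CC4)c3c(=O)c2O)cc1`) reads > 40000 nM as a limit of the assay. Compound 3 (`COc1ccc(-c2oc3c(OC)c(OC)cc(OCCCCC(=O)NCc4ccccn4)c3c(=O)c2O)cc1`) reads > 40000 nM as a limit too.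

Compound 4 (`COc1ccc(-c2oc3c(OC)c(OC)cc(OCCCCCC(=O)N4CCN(C)CC4)c3c(=O)c2O)cc1`) is still unmeasured. The change is ((4-methylpiperazin-1-yl)carbonyl)methyl in place of butyl(methyl)carbamoyl on a saturated chain carbon, four bonds along the chain from an oxygen on an aromatic ring and puts ((4-methylpiperazin-1-yl)carbonyl)methyl in place of butyl(methyl)carbamoyl on a saturated chain carbon, four bonds along the chain from an oxygen on an aromatic ring.

Two readable steps bear on this. The first is an at least 3.7-fold lower number from compound 1 to compound 2 (0.56 log units; beyond the scatter) and involves the same 4-methylpiperazin-1-yl carbonyl end. The second is an at least 3.7-fold higher number from compound 2 to compound 3 (0.56 log units; beyond the scatter) and shows that another amide end also gives a higher number. Both sizes are bounds only, and a step that the two limits leave unreadable from compound 1 to compound 3 adds nothing. For the measured compounds named here, no measured pair separates chain from amide end.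

The expected step is a 2.8-fold higher number from compound 2 to compound 4 (0.44 log units; beyond the scatter) in this assay toward weaker inhibition, and a limit reading is quite possible. For compound 4 the estimate is 30000 nM with an expected range of 11000 nM to 80000 nM as its ends.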

Compound 4, half-maximal inhibitory concentration: 13200 nM
The estimate for compound 4 lay 2.3-fold (0.36 log units) above the measured number, within the range that was stated.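

The chain change alone gives an at least 3.0-fold lower number from compound 1 to compound 4 (0.48 log units; beyond the scatter) in this assay, so the 4-methylpiperazin-1-yl carbonyl end does not rule out a measurable reading on the 2-((4-methylpiperazin-1-yl)carbonyl)ethyl chain. The change from the butyl(methyl)carbamoyl end on the shorter chain gives a 1.2-fold higher number from compound 2 to compound 4 (0.09 log units; within the scatter), so this pair shows no readable difference. The change from the ((pyridin-2-yl)methyl)carbamoyl end gives an at least 3.0-fold lower number from compound 3 to compound 4 (0.48 log units; beyond the scatter), so the amide end and chain together can separate compounds in this series.

Chain and amide end remain unseparated in the pairs involving compound 4, and the 4-methylpiperazin-1-yl carbonyl end on the chain of compound 2, a longer chain still, and a carboxylic acid in place of the amide remain open. The steps from compound 1 and compound 3 remain bounds only: the limit of > 40000 nM in this assay, at which 2 of the 4 values shown sit.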